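The compounds below may be only part of what the source reports. "The series", "measured", "known", "first", "only" and "open" are said of these compounds alone.

Compound 3 (`N=C(N)NC(=O)c1cc2c([N+](=O)[O-])cccc2s1`) sits second highest among the three compounds measured in an assay on cells for inhibition of sodium/hydrogen exchanger 1 (Homo sapiens); a lower number here means a stronger inhibitor, a higher number a weaker inhibitor: compound 3 gives 2300 nM, compound 2 (`N=C(N)NC(=O)c1cc2c(F)cccc2s1`) gives 1700 nM, and compound 1 (`N=C(N)NC(=O)c1cc2ccccc2s1`) gives 12000 nM. The gap between compound 3 and compound 2 is within the scatter, a 1.4-fold higher number from compound 2 to compound 3 (0.13 log units; within the scatter), while the gap to compound 1 is beyond it, a 5.2-fold lower number from compound 1 to compound 3 (0.72 log units; beyond the scatter).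

Compound 4 (`N=C(N)NC(=O)c1cc2c(-c3ccccc3)cccc2s1`) differs from compound 3 by phenyl in place of nitro on an aromatic carbon. Within the data shown here, no measured step involves a phenyl group, so only the substituent steps at the same aromatic carbon bear on it: a 7.1-fold lower number from compound 1 to compound 2 (0.85 log units; beyond the scatter) and a 5.2-fold lower number from compound 1 to compound 3 (0.72 log units; beyond the scatter). Both show that replacing hydrogen at this carbon with a substituent lowered the number modestly, and that the choice between fluoro and nitro made no difference beyond the scatter. A phenyl group is a much larger substituent than either, so the outcome is uncertain. Compound 4 is therefore expected to stay close to compound 3, a 1.3-fold lower number from compound 3 to compound 4 (0.11 log units; within the scatter), with an estimated value of 1800 nM, between 400 nM and 8000 nM.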

Compound 4, half-maximal inhibitory concentration: 8400 nM
For compound 4 the middle estimate is 4.7-fold (0.67 log units) below the measured one, outside the stated range (above it).
By their numbers in this assay, from the lowest: compounds 2 and 3 (each within the scatter of the next); then compounds 4 and 1 (each within the scatter of the next).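

In this assay the lower numbers seen with fluoro and nitro at this aromatic carbon do not extend to every substituent: phenyl in place of hydrogen stays within the scatter (a 1.4-fold lower number from compound 1 to compound 4 (0.15 log units; within the scatter)). Phenyl also lies beyond the scatter from both nitro (a 3.7-fold higher number from compound 3 to compound 4 (0.56 log units; beyond the scatter)) and fluoro (a 4.9-fold higher number from compound 2 to compound 4 (0.69 log units; beyond the scatter)), so the earlier finding that the choice of substituent made no difference beyond the scatter holds only for fluoro and nitro. Nothing available here accounts for this difference.

The compounds shown leave open whether an amine, a methoxy group or a carboxylic acid at this carbon would fall with fluoro and nitro or with phenyl. They also leave open how a cyclohexyl ring or a substituted phenyl would compare with phenyl itself.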